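Amide series: 3-ethylphenyl to 3-bromophenyl

This account rests on a few compounds, and the source may have more. Where it says the series, first, only, none or still open, it means among the compounds named here.

In a physicochemical assay, with a stated time of 30 min (a lower number here means a stronger inhibitor, a higher number a weaker inhibitor), compound 1 `COc1cc2c(cc1OC)C(=O)C(C(=O)Nc1ccc(Br)cc1)C2` gives 72.1 ug/mL. Compound 2 `CCc1cccc(NC(=O)C2Cc3cc(OC)c(OC)cc3C2=O)c1` gives 64.1 ug/mL, which places it level with compound 1 within the scatter, so the two numbers do not separate the pair. Among the compounds with values here, the single measured step, a 1.1-fold lower number from compound 1 to compound 2 (0.05 log units; within the scatter), puts 3-ethylphenyl in place of 4-bromophenyl on an amide-type nitrogen.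

Compound 3 `COc1cc2c(cc1OC)C(=O)C(C(=O)Nc1cccc(Br)c1)C2` has not yet been measured in this assay. It differs from compound 2 by bromo in place of ethyl on an aromatic carbon, meta to a large group: bromo in place of ethyl on an aromatic carbon.

Within the data shown here, no measured step covers this exact exchange. The closest evidence is the step that links the 4-bromophenyl and 3-ethylphenyl amides, a 1.1-fold lower number from compound 1 to compound 2 (0.05 log units; within the scatter), and that step stays within the scatter. Two measured compounds make a thin basis, so no direction can be argued and no change beyond the scatter is expected. The expected step is a 1.1-fold higher number from compound 2 to compound 3 (0.03 log units; within the scatter). Compound 3 is estimated at 68 ug/mL, with an expected range of 35 ug/mL to 130 ug/mL.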

Compound 3, half-maximal inhibitory concentration: 58.9 ug/mL
Estimate against measurement, compound 3: 1.2-fold (0.06 log units) above; the range from low to high includes it.
By their numbers in this assay, from the lowest: compounds 3, 2 and 1 (each within the scatter of the next).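

In this assay, bromo in place of ethyl on an aromatic carbon, meta to a large group, gives a 1.1-fold lower number from compound 2 to compound 3 (0.04 log units; within the scatter) and so shows that this place carries either group with no change that can be told from the scatter. Within the data shown here, the shift of the bromo, read as 3-bromophenyl in place of 4-bromophenyl on the amide-type nitrogen, gives a 1.2-fold lower number from compound 1 to compound 3 (0.09 log units; within the scatter) and is the first step to alter only where the same group sits on the aromatic ring, and it too stays within the scatter. No measurement bears on why either exchange leaves the number within the scatter.

The compounds shown leave open whether any substituent on this aromatic ring can move the number beyond the scatter, since all three compounds stand level and give no trend to read. An amine, a carboxylic acid or a longer chain on the same aromatic carbon would test that question, as would any change to the shared core.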